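A few compounds are considered here, and "the series" means these few. Any claim that something is new, unique, unknown or untested is made for them only; others in the source may bear on it.

The series shares one core, seen in compound 1 `COc1ccc(C2=C(c3cc(OC)c(OC)c(OC)c3)C(=O)C(O[SiH2]C(C)(C)C)C2)cc1OC(C)C`, compound 2 `COc1ccc(C2=C(c3cc(OC)c(OC)c(OC)c3)C(=O)C(O)C2)cc1NC(=O)c1ccccc1` and compound 3 `COc1ccc(C2=C(c3cc(OC)c(OC)c(OC)c3)C(=O)CC2O)cc1`, and all three were tested in an ADME assay on HEK293 cells (Homo sapiens) for cytotoxicity, read by MTT assay, with a stated time of 72 h; a higher number here means a weaker inhibitor, a lower number a stronger inhibitor. Compound 1 returns only a limit, > 100 ug/mL. Compound 2 likewise returns only a limit, > 100 ug/mL. Going by the values given here, compound 3 is the one compound of the three with a measured number, giving 10 ug/mL in this assay. Compounds 1 and 2 sit at the limit of > 100 ug/mL in this assay, at which 2 of the 3 values shown sit. Among the compounds with values here, no step between two measured compounds that differ in a single place can be drawn from these three.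

Compound 4 `COc1cc(C2=C(c3ccc(OCC(=O)O)cc3)C(O)CC2=O)cc(OC)c1OC` has not yet been measured. Relative to compound 3 its change is carboxy in place of hydrogen on a saturated chain carbon bound to an oxygen on an aromatic ring. Within the data shown here, no single-place step among the measured compounds is available to size this change. Compound 4 is nonetheless expected to be a weaker inhibitor in this assay than compound 3, by a step of a 5.0-fold higher number from compound 3 to compound 4 (0.70 log units; beyond the scatter) that would lie beyond the usual scatter. Compound 4 is therefore estimated at 50 ug/mL, with a range from 12 ug/mL to 100 ug/mL, and it may well return only a limit.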

Compound 4, half-maximal inhibitory concentration: > 100 ug/mL
Compound 4 was reported as a limit (the forecaster's own chance of this, stated with the estimate: 40%); middle value at least 2.0-fold (0.30 log units) from the limit.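

At this place, on a saturated chain carbon bound to an oxygen on an aromatic ring, the series now has its first step that can be read from a single change. In this assay, carboxy in place of hydrogen gives an at least 10-fold higher number from compound 3 to compound 4 (1.00 log units; beyond the scatter), so this one change alone moves the number beyond the scatter, towards a weaker inhibitor. Compound 4 returns a limit and not a number, and it joins the compounds that sit there: the limit of > 100 ug/mL in this assay, at which 3 of the 4 values shown sit.

Going by these compounds, how far the step truly reaches stays open, since only its lower bound can be read, and the data cannot separate the carboxylic acid from the added chain length. On these data alone, whether a methyl ester, an amide, an amine or a longer chain ending in a carboxylic acid at this place would give a similar step also remains unknown.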